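The source may hold more compounds than are shown below. What is called first, only, known or untested is meant among the compounds shown, and "the series" means these compounds.

Values in an ADME assay on HeLa cells (Homo sapiens) for cytotoxicity, read by resazurin assay, with a stated time of 2 days (a lower number here means a stronger inhibitor, a higher number a weaker inhibitor), so far:
compound 1 `Cc1cccc(/C=C/c2ncc([N+](=O)[O-])n2C)c1` gives 30900 nM
compound 2 `Cn1c([N+](=O)[O-])cnc1/C=C/c1ccccc1Br` gives 72400 nM
compound 3 `Cn1c([N+](=O)[O-])cnc1/C=C/c1ccc(Cl)cc1` gives 91200 nM

Compound 1 has the lowest number of the three, and the values of compound 2 and compound 3 both lie higher, beyond the usual scatter. For the measured compounds named here, no two measured compounds differ in one place only, so no clean single-change step is available to guide the next reading.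

Compound 4 `Cn1c([N+](=O)[O-])cnc1/C=C/c1cccc(F)c1` has yet to be measured in this assay. Against compound 1 it shows fluoro in place of methyl on an aromatic carbon and reads as fluoro in place of methyl on an aromatic carbon, meta to a large group.

Going by the values given here, the only guide is that compound 2 (72400 nM) and compound 3 (91200 nM) carry a halogen on that ring and both read higher than the methyl compound, compound 1 (30900 nM). A modest rise is therefore expected, though three compounds make thin support. The expected change is a 1.9-fold higher number from compound 1 to compound 4 (0.29 log units; within the scatter) as estimated here. For compound 4 the estimated value is 60000 nM with an expected range from 25000 nM to 130000 nM in this reading.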

Compound 4, half-maximal inhibitory concentration: > 100000 nM
Compound 4 ended at the assay's limit (the forecaster's own chance of this, stated with the estimate: 10%); middle value at least 1.6-fold (0.22 log units) away from the limit.
By their numbers in this assay, from the lowest: compound 1; then compounds 2 and 3 (each within the scatter of the next). At a limit, above all of these: compound 4.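

In this assay, the series now has its first single-change step: fluoro in place of methyl on an aromatic carbon, meta to a large group, gives an at least 3.2-fold higher number from compound 1 to compound 4 (0.51 log units; beyond the scatter). Compound 4 gives > 100000 nM, which is a limit of the assay and not a number: the limit of > 100000 nM in this assay, at which 1 of the 4 values shown sits. For the compounds shown here, at this position, the exchange of these two groups therefore moves the reading beyond the scatter, which the earlier compounds, with no pair differing in one place, could not show.

The true value of compound 4 remains unknown, and the data shown do not tell why the exchange has this effect. Also open, on these data alone, is whether an amine, a methoxy group or a longer chain at this same place would read closer to compound 1 or to compound 4.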